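The source may hold more compounds than are shown below. What is called first, only, known or untested is meant among the compounds shown, and "the series" means these compounds.

Compound 1, `O=C(CCc1ccccc1)Nc1ccc2sc(C(=O)NO)cc2c1`: in a functional assay on HCT-116 cells (Homo sapiens) for cytotoxicity, read by resazurin assay, with a stated time of 5 days (a higher number here means a weaker inhibitor, a lower number a stronger inhibitor), compound 1 has "not determined" (no result reported).
Compound 2, `N[C@@H](CCc1ccccc1)C(=O)Nc1ccc2cc(C(=O)NO)sc2c1`: in this assay compound 2 gives 3400 nM.

Compound 2 thus stands on the only number shown here; compound 1 carries no figure to compare with. Compound 3, `N[C@H](CCc1ccccc1)C(=O)Nc1ccc2cc(C(=O)NO)sc2c1`, is not yet measured. Its difference from compound 2 is the two compounds have the same atoms and bonds and differ only in configuration as drawn: 1 of 1 stereo elements differ; a stereocentre at a saturated chain carbon is drawn S in compound 2 and R in compound 3. Within the data shown here, no step between measured compounds is available to guide the estimate, so the step in this assay is expected to be modest, most likely a small loss, though a change within the scatter is also plausible. Compound 3 is therefore estimated at 5000 nM (range 1500 nM to 15000 nM), a step of a 1.5-fold higher number from compound 2 to compound 3 (0.17 log units; within the scatter).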

Compound 3, half-maximal inhibitory concentration: 320 nM
The estimate for compound 3 lay 16-fold (1.19 log units) above the measured number; the measured number lies below the stated range.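

Configuration at this saturated chain carbon turns out to matter in this assay, which the earlier compounds could not show: going from S to R gives an 11-fold lower number from compound 2 to compound 3 (1.03 log units; beyond the scatter). The change in number can be tied to the stereocentre alone because nothing else separates the pair: the fact that compounds 2 and 3 differ only in the configuration as drawn

The compounds shown leave open whether the preference for R would persist if a hydroxyl group replaced the amine, or if a longer chain carried the phenyl ring. They also do not reveal how configuration produces this difference in the cells.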